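The source may hold more compounds than are shown below. What is called first, only, known or untested is meant among the compounds shown, and "the series" means these compounds.

Of the compounds shown here, three built on one shared core have been tested in a toxicity assay on THP-1 cells (Homo sapiens) for inhibition; a higher number here means that more compound is tolerated, a lower number that less compound is tolerated. Compound 1 `COc1ccc(-c2cnc(NC(=O)c3cccc(C#N)c3)n2C)cc1` carries a 3-cyanophenyl on the carbonyl carbon, and in this assay compound 1 gives only a limit, > 100000 nM. Compound 2 `COc1ccc(-c2cnc(NC(=O)c3ccccc3Br)n2C)cc1` carries a 2-bromophenyl there, and compound 2 likewise reaches only the limit, > 100000 nM. Compound 3 `COc1ccc(-c2cnc(NC(=O)c3ccc(C#N)cc3)n2C)cc1` carries a 4-cyanophenyl, and compound 3 also sits at the limit, > 100000 nM. Compound 3 thus stands at the limit of > 100000 nM in this assay, at which 3 of the 3 values shown sit. The steps a step that the two limits leave unreadable from compound 1 to compound 2, a step that the two limits leave unreadable from compound 1 to compound 3 and a step that the two limits leave unreadable from compound 2 to compound 3 have no readable size, as each joins two limits.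

Compound 4 `COc1ccc(-c2cnc(NC(=O)c3cccc(Cl)c3)n2C)cc1` has not yet been measured. 3-chlorophenyl in place of 4-cyanophenyl on a carbonyl carbon The measured steps that bear on this change are a step that the two limits leave unreadable from compound 1 to compound 3 and a step that the two limits leave unreadable from compound 2 to compound 3, each exchanging one aromatic group for another on the carbonyl carbon, and neither shows a size or a direction. Among the measured compounds shown here, no measured step points toward more or less tolerated compound after such an exchange, so no step beyond the scatter is expected. The expected step of a number no higher from compound 3 to compound 4 (the limit leaves the size open) is therefore none beyond the scatter. Compound 4 is expected to give 100000 nM, with a range from 50000 nM to 200000 nM.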

Compound 4, half-maximal cytotoxic concentration: > 28000 nM
Compound 4 gave a limit, no number; the forecaster's own chance of this, stated with the estimate: 85%; the middle value lies beyond the limit too.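

In this assay compound 4 gives only a limit, > 28000 nM, not a number. Among the compounds shown here, compounds 1, 2 and 3 also give only limits, so no step from any of them to compound 4 can be read. The compounds shown leave open at what concentration each becomes toxic, and whether exchanging the aromatic group on the carbonyl carbon changes that concentration at all.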